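The source may report more compounds than this note shows. Statements on the series, on what has been measured and on what is new or still open speak of the compounds shown alone.

Among the measured compounds shown here, compound 1 `CC(C)COC(=O)N1CCN(C(=O)c2nc(Nc3cc(C4CC4)[nH]n3)c3cc(Cl)ccc3n2)C[C@H]1C` gives 30.7% in an assay for inhibition of serine/threonine-protein kinase PAK 4 (Homo sapiens), read by FRET and Z'-LYTE, with a stated time of 60 min, tested at 5 uM, in the presence of a further agent that is not named here (on this read-out higher numbers stand for a stronger effect at the one concentration tested and lower numbers for a weaker effect), the second highest of the three numbers measured so far. Compound 2 `C[C@@H]1CN(C(=O)c2nc(Nc3cc(C4CC4)[nH]n3)c3cc(Cl)ccc3n2)CCN1C(=O)OCc1ccccc1` gives 74% in this assay, and compound 3 `CCCCCOC(=O)N1CCN(C(=O)c2nc(Nc3cc(C4CC4)[nH]n3)c3cc(Cl)ccc3n2)C[C@H]1C` gives 12.6%. Both measured neighbours differ from compound 1 at the same place: a number 43.3 percentage points higher from compound 1 to compound 2 (beyond the scatter), and a number 18.1 percentage points lower from compound 1 to compound 3 (beyond the scatter), while a number 61.4 percentage points lower from compound 2 to compound 3 (beyond the scatter). Compound 4 `CCOC(=O)N1CCN(C(=O)c2nc(Nc3cc(C4CC4)[nH]n3)c3cc(Cl)ccc3n2)C[C@H]1C` is not yet measured and differs from compound 1 by methyl in place of isopropyl on a saturated chain carbon bound to an oxygen next to a carbonyl group. Neither measured step shortens the chain, so they bear on this one only by showing that a change at this place shifts this assay beyond the scatter in either direction; a modest step from compound 1 is expected, with the direction uncertain, a number 4.3 percentage points higher from compound 1 to compound 4 (within the scatter). The estimate for compound 4 in this assay is 35%, with a range from 15% to 55%.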

Compound 4, a percentage reported as inhibition, at one concentration (the size of the read-out at that concentration, not a potency): 79.2%
The estimate for compound 4 lay 44.2 percentage points below the measured number; the whole stated range lies below it.
By their numbers in this assay, from the lowest: compound 3; then compound 1; then compounds 2 and 4 (each within the scatter of the next).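

Shortening the group at this place brings a large gain in this assay (a number 48.5 percentage points higher from compound 1 to compound 4 (beyond the scatter)) and a larger-looking one against the longer chain (a number 66.6 percentage points higher from compound 3 to compound 4 (beyond the scatter)). The phenyl and methyl groups on this carbon are not separated (a number 5.2 percentage points higher from compound 2 to compound 4 (within the scatter)), so compound 2 goes against any reading that larger groups lower the number. No measured evidence on the cause of these steps is available here.

Still open, on these data alone, is how a cyclopropyl group or a pyridine ring would read at this place. These single-concentration readings also leave the potency of compound 2 and compound 4 open.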